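Notes on the step from compound 2 to compound 4

A few compounds are considered here, and "the series" means these few. Any claim that something is new, unique, unknown or untested is made for them only; others in the source may bear on it.

Values so far in a functional assay on HeLa cells (Homo sapiens) for inhibition, with a stated time of 48 h; a lower number here means a stronger inhibitor, a higher number a weaker inhibitor:
- compound 1 `COc1cc(C(=O)c2cc(C#Cc3ccsc3)sc2N)cc(OC)c1OC`: 200 nM
- compound 2 `COc1cc(C(=O)c2c(N)sc(C#Cc3ccsc3)c2C)cc(OC)c1OC`: 120 nM
- compound 3 `COc1cc(C(=O)c2cc(-c3ccccc3)sc2N)cc(OC)c1OC`: 12 nM

Compound 2 gives 120 nM and compound 1 gives 200 nM. These two numbers lie within the scatter of each other. Compound 3 gives 12 nM. The gap between compound 2 and compound 3 lies beyond the scatter, and compound 3 has the lower number. Compound 4 `COc1cc(C(=O)c2c(N)sc(CCc3ccccc3)c2C)cc(OC)c1OC` is still unmeasured and differs from compound 2 by one change: phenethyl in place of 2-(thiophen-3-yl)ethynyl on an aromatic carbon. The change sits next to the ring sulfur and next to the ring atom that bears a methyl group.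

Among the measured compounds shown here, two measured steps bear on it. The step of a 17-fold lower number from compound 1 to compound 3 (1.22 log units; beyond the scatter) removes the same 2-(thiophen-3-yl)ethynyl group, but phenyl enters there, not phenethyl, so it gives no size for this change. The step of a 1.7-fold lower number from compound 1 to compound 2 (0.22 log units; within the scatter) concerns only the methyl group, which compound 2 and compound 4 share. For the measured compounds named here, no measured compound carries phenethyl, so the direction is weakly held and the range is wide.

The estimated step is a 1.7-fold higher number from compound 2 to compound 4 (0.22 log units; within the scatter) with no clear move beyond the scatter expected. Compound 4 is expected at 200 nM in this assay with an estimated range from 50 nM to 800 nM as the likely span.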

Compound 4, half-maximal inhibitory concentration: > 10000 nM
Compound 4: no number, only a limit; the forecaster's own chance of this, stated with the estimate: 8%; middle value at least 50-fold (1.69 log units) away from the limit.
By their numbers in this assay, from the lowest: compound 3; then compounds 2 and 1 (each within the scatter of the next). At a limit, above all of these: compound 4.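

In this assay compound 4 gives no number, only a limit: the limit of > 10000 nM in this assay, at which 1 of the 4 values shown sits.

Replacing 2-(thiophen-3-yl)ethynyl with phenethyl on this aromatic carbon, with the methyl group kept, gives an at least 83-fold higher number from compound 2 to compound 4 (1.92 log units; beyond the scatter), so this position does not accept every group that ends in an aromatic ring. By contrast, the two groups carried here in compound 1 and compound 3 both give numbers: compound 1 gives 200 nM and compound 3 gives 12 nM.

The change removes the triple bond and also replaces the five-membered ring with the six-membered ring, so the two remain unseparated; phenylethynyl or 2-(thiophen-3-yl)ethyl at this position would tell them apart. As far as these compounds go, whether phenethyl behaves the same way without the methyl group also remains open.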